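The source may report more compounds than this note shows. Statements on the series, on what has been measured and on what is new or still open speak of the compounds shown alone.

Measured compounds and their values in a functional assay on the whole organism (spleen, spleen) with Rattus norvegicus as the target; a lower number here means that less compound is needed, a higher number that more compound is needed for the effect:

Compound 1, `C=CCC(N)(CO)CCc1ccc(OCCCCCCC)cc1`: 3.1 mg/kg
Compound 2, `CCCCCCCOc1ccc(CCC(N)(CO)C(C)C)cc1`: 4.5 mg/kg
Compound 3, `CCCCCCCOc1ccc(CC[C@@](N)(CO)CCC)cc1`: 4.4 mg/kg

Compound 3 stands close to both of its neighbours: one step is a 1.0-fold lower number from compound 2 to compound 3 (0.01 log units; within the scatter), and the other is a 1.4-fold higher number from compound 1 to compound 3 (0.15 log units; within the scatter), so all three measured values sit together within the scatter of this assay. The step of a 1.5-fold higher number from compound 1 to compound 2 (0.16 log units; within the scatter) shows the same picture for the other pair.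

Compound 4, `CCCCCCCOc1ccc(CC[C@@](N)(CO)CCO)cc1`, differs from compound 3 by hydroxy in place of methyl on a saturated chain carbon, three bonds along the chain from an amine nitrogen; cut one bond further out, the same change reads ethyl to hydroxymethyl, or propyl to 2-hydroxyethyl. The three measured steps all alter the group on the same saturated chain carbon next to the amine-bearing centre, and none of them moved the number beyond the scatter. None, however, introduced a hydroxy, so the data give no direct guide to such a change. The expected step of a 1.1-fold higher number from compound 3 to compound 4 (0.06 log units; within the scatter) is therefore one within the scatter, with no clear direction. Compound 4 is estimated at 5 mg/kg, within the range 2 mg/kg to 12 mg/kg.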

Compound 4, dose for 50% inhibition: 0.018 mg/kg
Compound 4: middle estimate off by 280-fold (2.44 log units), on the high side; the measured number lies below the stated range.
By their numbers in this assay, from the lowest: compound 4; then compounds 1, 3 and 2 (each within the scatter of the next).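

In this assay, going by these compounds alone, hydroxy in place of methyl, on a saturated chain carbon three bonds along the chain from an amine nitrogen, gives the first large step in this set (a 240-fold lower number from compound 3 to compound 4 (2.39 log units; beyond the scatter)), whereas the allyl, isopropyl and propyl compounds all lie within the scatter of one another. The steps from the other two compounds are of similar size (a 250-fold lower number from compound 2 to compound 4 (2.40 log units; beyond the scatter); a 170-fold lower number from compound 1 to compound 4 (2.24 log units; beyond the scatter)), so the result does not depend on which of the three serves as the comparison. Nothing measured here bears on why this single change has so large an effect.

The compounds shown leave open whether another group at this place, such as an amine, a methoxy or a carboxylic acid, would give a similar step. They also leave open how a hydroxymethyl or a 3-hydroxypropyl group would compare with the 2-hydroxyethyl group of compound 4.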